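A few compounds are considered here, and "the series" means these few. Any claim that something is new, unique, unknown or untested is made for them only; others in the source may bear on it.

Compound 1 `COc1ccc2nc(C)cc(OCC(=O)Nc3ccccc3)c2c1` and compound 2 `COc1ccc2nc(C)cc(OCC(=O)Nc3ccc(C)cc3)c2c1` differ by one change, (methyl in place of hydrogen on an aromatic carbon), set on an aromatic carbon of a six-membered aromatic ring of carbon only, para to a large group. In an ADME assay on HepG2 cells (Homo sapiens) for cytotoxicity, read by trypan blue exclusion, with a stated time of 48 h, in the presence of a further agent that is not named here (a lower number here means that less compound is tolerated, a higher number that more compound is tolerated), compound 1 reaches only a limit, > 155000 nM. In this assay compound 2 likewise reaches only a limit, > 149000 nM. The step that the two limits leave unreadable from compound 1 to compound 2 cannot be read, since both values sit at limits, the limit of > 149000 nM in this assay, at which 1 of the 3 values shown sits, and (the limit of > 155000 nM in this assay, at which 1 of the 3 values shown sits). Compound 3 `COc1ccccc1NC(=O)COc1cc(C)nc2ccccc12` has the same atoms as compound 1, joined differently; how the two cores differ is not broken down here. In this assay, among the measured compounds shown here, compound 3 gives 43900 nM, the only number among the three values. Compound 4 `COc1ccccc1NC(=O)COc1cc(C)nc2ccc(C)cc12` carries the same kind of change relative to compound 3, (methyl in place of hydrogen on an aromatic carbon), but here the methyl sits on a six-membered aromatic ring of carbon only that is part of a fused or bridged system of two rings, meta to a fused ring and para to a fused ring. For the measured compounds named here, the sole measured instance of this change, a step that the two limits leave unreadable from compound 1 to compound 2, offers no size to lean on. The expected step of a 1.1-fold higher number from compound 3 to compound 4 (0.06 log units; within the scatter) is therefore small, resting on compound 3 at 43900 nM. Compound 4 is estimated at 50000 nM, between 20000 nM and 150000 nM.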

Compound 4, half-maximal cytotoxic concentration: > 74000 nM
Compound 4: no number, only a limit; the forecaster's own chance of this, stated with the estimate: 25%; at least 1.4-fold (0.17 log units) between middle value and limit.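

In this assay, methyl in place of hydrogen on an aromatic carbon gives an at least 1.6-fold higher number from compound 3 to compound 4 (0.22 log units; that floor lies within the scatter), so on the core of compound 3 the change brings no fall in the number, though this floor alone does not establish a real rise. Going by these compounds, compound 4 gives > 74000 nM, which is a limit and not a number, so the full size of the step remains unknown: the limit of > 74000 nM in this assay, at which 1 of the 4 values shown sits. The step from compound 1 to compound 2 cannot be read, and the methyl sits on a different ring there, so these compounds do not show whether the change carries from one core to the other with the same size.

The compounds shown leave open how the number would move with an amine or a carboxylic acid in place of the methyl on either core. On these data alone, whether a longer chain at the same place would give a step that can be read in this assay also remains open.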